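Replacing the aryl group of compound 3 with 4-aminophenyl

This account rests on a few compounds, and the source may have more. Where it says the series, first, only, none or still open, it means among the compounds named here.

In a functional assay on A549 cells (Homo sapiens) for antiproliferative activity, read by MTT assay, with a stated time of 48 h (a lower number here means a stronger inhibitor, a higher number a weaker inhibitor), compound 3 `COc1cc(-c2nc3cccc(-c4cc(OC)c(OC)c(OC)c4)c3o2)ccc1O` gives 15700 nM, the higher of the two exact numbers available. Compound 1 `COc1cc(-c2cccc3nc(-c4cccc(Br)c4)oc23)cc(OC)c1OC` gives 2100 nM, and the step between them is a 7.5-fold higher number from compound 1 to compound 3 (0.87 log units; beyond the scatter). Compound 2 `COc1cc(-c2cccc3nc(-c4cccc(Cl)c4)oc23)cc(OC)c1OC` is reported only as a limit, > 25000 nM.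

Compound 4 `COc1cc(-c2cccc3nc(-c4ccc(N)cc4)oc23)cc(OC)c1OC` carries 4-aminophenyl in place of 4-hydroxy-3-methoxyphenyl, on an aromatic carbon of a five-membered aromatic ring with 1 nitrogen and 1 oxygen (4-aminophenyl in place of 4-hydroxy-3-methoxyphenyl on an aromatic carbon). Changes to this group have been able to move the number a long way: besides the step above, there is an at least 11-fold higher number from compound 1 to compound 2 (1.07 log units; beyond the scatter). The remaining comparison, an at least 1.5-fold lower number from compound 2 to compound 3 (0.20 log units; that floor lies within the scatter), has a floor within the scatter. Neither compound 3 nor compound 4 carries bromo or chloro, so the value of compound 3, 15700 nM, serves as the starting point, with little reason to expect a large shift in either direction. The estimated step is a 1.4-fold lower number from compound 3 to compound 4 (0.15 log units; within the scatter), so no clear change is expected. For compound 4 the expected value is 11000 nM, with an estimated range of 2500 nM to 35000 nM.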

Compound 4, half-maximal inhibitory concentration: 720 nM
For compound 4 the middle estimate is 15-fold (1.18 log units) above the measured one, outside the stated range (below it).
By their numbers in this assay, from the lowest: compound 4; then compound 1; then compound 3. At a limit, above all of these: compound 2.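

At this position, on an aromatic carbon of a five-membered aromatic ring with 1 nitrogen and 1 oxygen, 4-aminophenyl gives the lowest number yet in this assay, with a 22-fold lower number from compound 3 to compound 4 (1.34 log units; beyond the scatter) and a 2.9-fold lower number from compound 1 to compound 4 (0.46 log units; beyond the scatter). Going by these compounds alone, both earlier changes from compound 1 raised the number, so this is the first change at this position to lower it, and an at least 34-fold lower number from compound 2 to compound 4 (1.54 log units; beyond the scatter) is also large. Compound 2 stands only as a limit, so that last step is a floor and not an exact size: the limit of > 25000 nM in this assay, at which 1 of the 4 values shown sits.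

The compounds shown do not separate the effect of the amine from that of its place on the phenyl ring. A 3-aminophenyl group would address the place, while a 4-(dimethylamino)phenyl or 4-acetamidophenyl group would show whether the free amine is needed.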